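Dropping One Trifluoromethyl: From Compound 2 to Compound 4

This account rests on a few compounds, and the source may have more. Where it says the series, first, only, none or still open, it means among the compounds named here.

Three close relatives have so far been tested in a functional assay on ACHN cells (Homo sapiens) for inhibition, read by sulforhodamine B assay, with a stated time of 48 h; on this read-out lower numbers stand for higher toxicity in this test and higher numbers for lower toxicity in this test. Compound 1 `O=C(Nc1cccc(-n2cc(-c3ccncc3)c(-c3ccc(Cl)c(O)c3)n2)c1)Nc1cccc(C(F)(F)F)c1` reaches only a limit there, giving > 32500 nM. Compound 2 `COc1cc(-c2nn(-c3cccc(NC(=O)Nc4cc(C(F)(F)F)cc(C(F)(F)F)c4)c3)cc2-c2ccncc2)ccc1Cl` likewise gives only a limit, > 50000 nM. Compound 3 `COc1cc(-c2nn(-c3cccc(NC(=O)Nc4ccc(Cl)c(Cl)c4)c3)cc2-c2ccncc2)ccc1Cl` also stops at a limit, with > 50000 nM. Compound 2 therefore cannot be placed on a scale: its value is one limit among three, and the other two are limits as well, as the limit of > 32500 nM in this assay, at which 1 of the 3 values shown sits, and the limit of > 50000 nM in this assay, at which 2 of the 3 values shown sit, describe. Within the data shown here, no step between two measured numbers can be drawn from such data.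

Compound 4 `COc1cc(-c2nn(-c3cccc(NC(=O)Nc4cccc(C(F)(F)F)c4)c3)cc2-c2ccncc2)ccc1Cl` has not yet been measured. It differs from compound 2 in one place: hydrogen in place of trifluoromethyl on an aromatic carbon. The same aryl urea carrying a single trifluoromethyl already appears in compound 1, which also reached only a limit. Nothing measured here suggests that this change would move the read-out beyond the scatter in this assay. The expected step is one of no size beyond the scatter, a number no higher from compound 2 to compound 4 (the limit leaves the size open). Compound 4 is therefore expected to sit at 50000 nM, within 20000 nM to 150000 nM, and most likely it will again be reported only as a limit.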

Compound 4, concentration lethal to 50% of the cells: > 50000 nM
Compound 4 ended at the assay's limit (the forecaster's own chance of this, stated with the estimate: 85%); the middle value lies on the limit itself.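

Compound 4 gives > 50000 nM in this assay, which is a limit of the assay and not a number. The steps linking compound 4 to compound 1, compound 2 and compound 3 cannot be read, as all four values are limits. The compounds shown leave open whether any of these structural changes alters the read-out in this assay.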